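The source may report more compounds than this note shows. Statements on the series, on what has been measured and on what is new or still open speak of the compounds shown alone.

Measured in a functional assay on KB cells (Homo sapiens) for antiproliferative activity, read by sulforhodamine B assay, with a stated time of 3 days; on this read-out lower numbers stand for an effect already at smaller amounts and higher numbers for an effect only at larger amounts of compound:
Compound 1 `CCC1=C(O)c2c(oc(-c3ccccc3)cc2=O)C(CC)(CC)C1=O`: > 236 uM, a limit.
Compound 2 `CCCc1ccc(-c2cc(=O)c3c(o2)C(CC)(CC)C(=O)C(CC)=C3O)cc1`: > 53 uM, a limit.
Compound 3 `CCC1=C(O)c2c(oc(-c3ccc(C(C)C)cc3)cc2=O)C(CC)(CC)C1=O`: 8.13 uM.

Compound 2 stands on a limit only, > 53 uM. Of the three, compound 3 alone carries a measured number. The next change leads to compound 4 `CCC1=C(O)c2c(oc(-c3ccc(C(F)(F)F)cc3)cc2=O)C(CC)(CC)C1=O`, with trifluoromethyl in place of propyl on an aromatic carbon.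

Among the measured compounds shown here, three measured steps concern this same aromatic carbon. The first, a step that the two limits leave unreadable from compound 1 to compound 2, gives no usable size. The second, an at least 29-fold lower number from compound 1 to compound 3 (1.46 log units; beyond the scatter), is large. The third, an at least 6.5-fold lower number from compound 2 to compound 3 (0.81 log units; beyond the scatter), shows that exchanging propyl for isopropyl alone can matter here. Compound 2 goes against any simple rule that an alkyl group at this carbon lowers the number, and compound 3 remains the single case with a measured value. For the measured compounds named here, no measured step brings in trifluoromethyl, so these steps carry over only weakly.

In this assay, no step beyond the scatter is expected, and a firm direction cannot be assigned. The expected step is an at least 1.3-fold lower number from compound 2 to compound 4 (0.12 log units; that floor lies within the scatter). Compound 4 may also be reported only as a limit. For compound 4 the estimated value is 40 uM. The expected range for compound 4 runs from 10 uM to 160 uM.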

Compound 4, concentration for half-maximal effect: 35.7 uM
The estimate for compound 4 lay 1.1-fold (0.05 log units) above the measured number, and the stated range covers the measured number.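

In this assay, among the compounds shown here, the exchange of isopropyl for trifluoromethyl gives a 4.4-fold higher number from compound 3 to compound 4 (0.64 log units; beyond the scatter), the first step at this aromatic carbon with a measured number at both ends, so the choice between two substituents here can be read as a real size. Trifluoromethyl in place of hydrogen gives an at least 6.6-fold lower number from compound 1 to compound 4 (0.82 log units; beyond the scatter), which shows that a lower number at this carbon does not need an alkyl group, although the size of this step is only a floor set by the limit of compound 1: the limit of > 236 uM in this assay, at which 1 of the 4 values shown sits. Trifluoromethyl in place of propyl gives an at least 1.4-fold lower number from compound 2 to compound 4 (0.17 log units; that floor lies within the scatter), so no order can be read for this pair, and compound 2 still goes against any rule that a group at this carbon brings a measured number, as it stands only on its limit: the limit of > 53 uM in this assay, at which 1 of the 4 values shown sits.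

From the compounds shown here alone, the real numbers behind the limits of compound 1 and compound 2 remain unknown, and with them the full size of every step that starts from either compound. Going by these compounds, how an amine, a carboxylic acid or a longer chain at this aromatic carbon would read in this assay also stays open.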